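The source may report more compounds than this note shows. Statements on the series, on what has been measured and on what is new or still open speak of the compounds shown alone.

Measured so far:
compound 1 `COc1ccc(C(=O)c2cc(OC)c(OC)c(OC)c2)cc1NC(=O)/C=C/c1ccc(OC)c(OC)c1` — 7800 nM
compound 2 `COc1ccc(C(=O)c2cc(OC)c(OC)c(OC)c2)cc1NC(=O)/C=C/c1ccc(C(F)(F)F)cc1` — 90 nM
compound 3 `COc1ccc(C(=O)c2cc(OC)c(OC)c(OC)c2)cc1NC(=O)/C=C/c1ccc(F)c(F)c1` — 8100 nM

In a functional assay on HeLa cells (Homo sapiens) for cytotoxicity, read by MTT assay, with a stated time of 72 h (a higher number here means a weaker inhibitor, a lower number a stronger inhibitor), compound 3 stands at the highest number of the three, but one of its two gaps is only a 1.0-fold higher number from compound 1 to compound 3 (0.02 log units; within the scatter), within the scatter; compound 2 lies far away, with a 90-fold higher number from compound 2 to compound 3 (1.95 log units; beyond the scatter). Compound 4 `COc1ccc(C(=O)c2cc(OC)c(OC)c(OC)c2)cc1NC(=O)/C=C/c1ccc([N+](=O)[O-])cc1` is the next step from compound 3: 4-nitrophenyl in place of 3,4-difluorophenyl on a double-bonded chain carbon bound to a double-bonded chain carbon.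

For the measured compounds named here, no measured step exchanges a 3,4-difluorophenyl or a 3,4-dimethoxyphenyl for a 4-nitrophenyl, so the step is not directly covered. Going by the values given here, what bears on it is that the only compound carrying a single group in the 4-position of that phenyl ring, compound 2, is the one that departs from the others, by an 87-fold lower number from compound 1 to compound 2 (1.94 log units; beyond the scatter) and by a 90-fold higher number from compound 2 to compound 3 (1.95 log units; beyond the scatter). Among the compounds with values here, compound 4 carries its single group in the same position, so a lower number than compound 3 in this assay is expected, though with wide uncertainty: the step is estimated as a 14-fold lower number from compound 3 to compound 4 (1.13 log units; beyond the scatter). Compound 4 is therefore expected near 600 nM, between 60 nM and 6000 nM.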

Compound 4, half-maximal inhibitory concentration: 8500 nM
Compound 4: the middle estimate sits 14-fold (1.15 log units) below what was measured, and the stated range ends below it.
By their numbers in this assay, from the lowest: compound 2; then compounds 1, 3 and 4 (each within the scatter of the next).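

With 4-nitrophenyl on the double-bonded chain carbon, the result in this assay is no different from that with 3,4-difluorophenyl, at a 1.0-fold higher number from compound 3 to compound 4 (0.02 log units; within the scatter), or with 3,4-dimethoxyphenyl, at a 1.1-fold higher number from compound 1 to compound 4 (0.04 log units; within the scatter). Nitro in place of trifluoromethyl on the aromatic carbon, the only change between these two compounds, gives a 94-fold higher number from compound 2 to compound 4 (1.98 log units; beyond the scatter), so among the four compounds the low number belongs to compound 2 alone and does not extend to compound 4, which also carries one group on that ring. Nothing measured here explains this difference between trifluoromethyl and nitro.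

The compounds shown leave open whether the low number is unique to trifluoromethyl or could also be reached with an amine, a carboxylic acid or a longer alkyl chain at that aromatic carbon. They also leave open whether a nitrile there would follow compound 2 or compound 4.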